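Clearance in mouse liver microsomes: moving to 2,4-difluorophenyl

This account rests on a few compounds, and the source may have more. Where it says the series, first, only, none or still open, it means among the compounds named here.

Three compounds sharing one core have been run in an in vitro ADME assay on microsomes from liver (Mus musculus) for pharmacokinetics, read by LC-MS, with a stated time of 10 min, tested at 1 uM; on this read-out lower numbers stand for slow clearance and higher numbers for fast clearance. Compound 1 `CN1C[C@H](C(=O)Nc2cccc(F)c2)[C@@H](c2ccc(/C=C/C(=O)Nc3ccccc3N)cc2)C1` gives 56 mL/min/kg. Compound 2 `CN1C[C@H](C(=O)Nc2cccc(Cl)c2)[C@@H](c2ccc(/C=C/C(=O)Nc3ccccc3N)cc2)C1` gives 58 mL/min/kg, and compound 3 `CN1C[C@H](C(=O)Nc2ccc(F)c(F)c2)[C@@H](c2ccc(/C=C/C(=O)Nc3ccccc3N)cc2)C1` gives 46 mL/min/kg. Compound 2 sits among these numbers with no separation that counts: the step of a 1.0-fold higher number from compound 1 to compound 2 (0.02 log units; within the scatter) and the step of a 1.3-fold lower number from compound 2 to compound 3 (0.10 log units; within the scatter) both lie within the scatter, as does a 1.2-fold lower number from compound 1 to compound 3 (0.09 log units; within the scatter).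

Compound 4 `CN1C[C@H](C(=O)Nc2ccc(F)cc2F)[C@@H](c2ccc(/C=C/C(=O)Nc3ccccc3N)cc2)C1` has not yet been measured. It differs from compound 2 in one place: 2,4-difluorophenyl in place of 3-chlorophenyl on an amide-type nitrogen.

The measured steps that bear on this change are those that alter the same aryl group on the amide-type nitrogen, namely a 1.0-fold higher number from compound 1 to compound 2 (0.02 log units; within the scatter), a 1.2-fold lower number from compound 1 to compound 3 (0.09 log units; within the scatter) and a 1.3-fold lower number from compound 2 to compound 3 (0.10 log units; within the scatter). None of them moves clearance beyond the scatter. The account therefore expects no step beyond the scatter from compound 2 to compound 4 in this assay, so that a 1.1-fold lower number from compound 2 to compound 4 (0.05 log units; within the scatter) is estimated as essentially flat. Compound 4 is expected to give about 52 mL/min/kg, with a range from 30 mL/min/kg to 90 mL/min/kg.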

Compound 4, clearance: 27 mL/min/kg
Beside the measured number, compound 4's estimate is 1.9-fold (0.28 log units) above it; the measured number lies below the stated range.
By their numbers in this assay, from the lowest: compounds 4, 3, 1 and 2 (each within the scatter of the next, the first and the last beyond it).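

In this assay, the aryl group on the amide-type nitrogen now gives steps beyond the scatter, which none of the earlier changes there did: a 2.1-fold lower number from compound 2 to compound 4 (0.33 log units; beyond the scatter) and a 2.1-fold lower number from compound 1 to compound 4 (0.32 log units; beyond the scatter) are both modest. The 2,4-difluorophenyl group does not separate from the 3,4-difluorophenyl group, however, as a 1.7-fold lower number from compound 3 to compound 4 (0.23 log units; within the scatter) stays within the scatter, so the separation holds only against the 3-chlorophenyl and 3-fluorophenyl groups. Nothing given here accounts for the difference between these groups.

The compounds shown leave open how a single fluoro group would read in the 2-fluorophenyl or 4-fluorophenyl group on this nitrogen, and so whether the step needs both fluorines. They also leave open how a plain phenyl or a 2,4-dichlorophenyl group would read at the same place.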